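Carboxy in Place of Hydroxymethyl on the Amide Side Chain

The source may hold more compounds than are shown below. What is called first, only, known or untested is meant among the compounds shown, and "the series" means these compounds.

Compound 1, `CCn1c(C(=O)N[C@H](C)C(=O)OC)ccc1C(CC)(CC)c1ccc(OCS(=O)(=O)c2ccccc2)c(C)c1`, gives > 50000 nM in a functional assay on PC-3 cells (Homo sapiens) for antiproliferative activity, read by MTT assay, with a stated time of 24 h; a lower number here means a stronger inhibitor, a higher number a weaker inhibitor.
Compound 2, `CCn1c(C(=O)N[C@@H](CO)C(C)C)ccc1C(CC)(CC)c1ccc(OCS(=O)(=O)c2ccccc2)c(C)c1`, gives 10600 nM in this assay.

The value of compound 1 is a limit of the assay, not a number (the limit of > 50000 nM in this assay, at which 1 of the 2 values shown sits). For the measured compounds named here, compound 2 therefore holds the only real number measured so far; the other value is a limit. Going by the values given here, the single measured step, an at least 4.7-fold lower number from compound 1 to compound 2 (0.67 log units; beyond the scatter), replaced one whole side chain with another and set compound 2 as the stronger of the pair.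

Compound 3, `CCn1c(C(=O)N[C@@H](C(=O)O)C(C)C)ccc1C(CC)(CC)c1ccc(OCS(=O)(=O)c2ccccc2)c(C)c1`, differs from compound 2 by a smaller change: carboxy in place of hydroxymethyl on a saturated chain carbon bound to an amide-type nitrogen and a saturated chain carbon. Among the compounds with values here, no measured step touches this exact exchange, and the one step known does not separate the part that changes here. With nothing pointing either way, the expectation is a step within the usual scatter, a 1.4-fold higher number from compound 2 to compound 3 (0.15 log units; within the scatter). Compound 3 is thus estimated at 15000 nM, with a range from 4000 nM to 50000 nM.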

Compound 3, half-maximal inhibitory concentration: 3070 nM
Estimate against measurement, compound 3: 4.9-fold (0.69 log units) above, and the stated range ends above it.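

In this assay, carboxy in place of hydroxymethyl gives a 3.5-fold lower number from compound 2 to compound 3 (0.54 log units; beyond the scatter), which shows that this one position on the side chain responds to a small exchange, with the rest of the molecule unchanged and the step beyond the scatter. Changing the whole side chain gives an at least 16-fold lower number from compound 1 to compound 3 (1.21 log units; beyond the scatter), so compound 3 is the stronger of that pair, though the size of the step has no upper bound. The value for compound 1 is a limit of the assay and not a number: the limit of > 50000 nM in this assay, at which 1 of the 3 values shown sits.

The compounds shown leave open whether an amine or a simple primary amide at this position would match the carboxy. They also leave open whether a longer chain in place of the 2-methylpropyl part would keep this level of activity.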